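Halogen change on the core aromatic carbon of compound 3

A few compounds are considered here, and "the series" means these few. Any claim that something is new, unique, unknown or untested is made for them only; others in the source may bear on it.

Compound 1 `CCCN(CCC)c1cc(C)nc2c(-c3ccc(C)nc3)c(C)nn12` gives 21 nM
Compound 2 `CCCN(CCC)c1c(F)c(C)nc2c(-c3cnc(N(C)C)cc3C)c(C)nn12` gives 5.6 nM
Compound 3 `CCCN(CCC)c1c(Cl)c(C)nc2c(-c3cnc(N(C)C)cc3C)c(C)nn12` gives 39 nM

In an assay on CHO cells for binding affinity to corticotropin-releasing factor receptor 1 (Homo sapiens) (on this read-out higher numbers stand for weaker inhibition and lower numbers for stronger inhibition), compound 3 has the highest of the three numbers; compound 1 sits within the scatter of it, compound 2 lies well below it. Compound 4 `CCCN(CCC)c1c(Br)c(C)nc2c(-c3cnc(N(C)C)cc3C)c(C)nn12` differs from compound 3 by bromo in place of chloro on an aromatic carbon. Within the data shown here, the only measured step touching this position is a 7.0-fold higher number from compound 2 to compound 3 (0.84 log units; beyond the scatter), fluoro to chloro at the same carbon. Chloro to bromo has no direct precedent here; the one step points to a modest move toward a higher number in this assay, possibly none beyond the scatter. Compound 4 is therefore expected at 60 nM with a range from 25 nM to 150 nM. The expected step is a 1.5-fold higher number from compound 3 to compound 4 (0.19 log units; within the scatter).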

Compound 4, inhibition constant: 240 nM
Compound 4: middle estimate off by 4.0-fold (0.60 log units), on the low side; measured number above the stated range.
By their numbers in this assay, from the lowest: compound 2; then compounds 1 and 3 (each within the scatter of the next); then compound 4.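

In this assay the sensitivity of this core aromatic carbon does not stop at chloro: bromo in place of chloro gives a 6.2-fold higher number from compound 3 to compound 4 (0.79 log units; beyond the scatter) and is beyond the scatter. Across the series, bromo in place of fluoro gives a 43-fold higher number from compound 2 to compound 4 (1.63 log units; beyond the scatter) and the numbers rise in the order fluoro, chloro, bromo for these three compounds. Nothing available explains this rise.

Open, on these data alone, is whether the order holds beyond halogens, for instance with a methoxy or a nitrile on this carbon. Compound 1 differs from these three in more than one place, so the effect of a bare ring hydrogen here stays unresolved.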